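From Methoxy to Hydroxy at the Assay Limit

A few compounds are considered here, and "the series" means these few. Any claim that something is new, unique, unknown or untested is made for them only; others in the source may bear on it.

Measured so far in an ADME assay on Raji cells (Homo sapiens) for cytotoxicity, read by luminescence, with a stated time of 72 h (a higher number here means that more compound is needed for the effect, a lower number that less compound is needed), as limits, not numbers:
- Compound 1 `C=Cc1cccc(-c2[nH]c3cc(OC)ccc3c(=O)c2C(=O)OCC)c1` gives > 21500 nM as a limit
- Compound 2 `CCOC(=O)c1c(-c2cccc(Oc3ccccc3)c2)[nH]c2cc(OC)ccc2c1=O` gives > 21500 nM as a limit

In this assay, from the compounds shown here alone, compound 2 stands at > 21500 nM and this is a limit, so its true position is unknown. Among the measured compounds shown here, the wider picture is the limit of > 21500 nM in this assay, at which 2 of the 2 values shown sit, and no compound has yet given a number. Compound 3 `CCOC(=O)c1c(-c2cccc(Oc3ccccc3)c2)[nH]c2cc(O)ccc2c1=O` differs from compound 2 by one small change (hydrogen in place of methyl on an oxygen on an aromatic ring) that turns methoxy to hydroxy, with hydrogen in place of methyl on an oxygen on an aromatic ring.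

For the measured compounds named here, the only measured step is a step that the two limits leave unreadable from compound 1 to compound 2 for phenoxy in place of vinyl on an aromatic carbon. It has no readable size and involves different groups, so it offers no direct guide to this change. No step beyond the usual scatter is therefore expected, and no direction can be favoured. The expected size is a step that the limit leaves unreadable from compound 2 to compound 3 and this estimate is loose. For compound 3 the estimate is 22000 nM with an expected range from 8000 nM to 50000 nM and a good chance that the assay again reports only a limit.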

Compound 3, half-maximal effective concentration: > 21500 nM
Compound 3: only a limit was reported; the forecaster's own chance of this, stated with the estimate: 75%; the middle value does not contradict the limit.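

In this assay compound 3 gives > 21500 nM, which is a limit and not a number. Among the compounds shown here, compound 2 also stands at a limit, so the change from methoxy to hydroxy between compound 2 and compound 3 gives no step that can be read. The compounds shown leave open how much of any of them is needed for the effect, with every value resting on one limit: the limit of > 21500 nM in this assay, at which 3 of the 3 values shown sit.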